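Swapping trifluoroethoxy for bromo on a weak compound

The compounds below may be only part of what the source reports. "The series", "measured", "known", "first", "only" and "open" are said of these compounds alone.

Values in a functional assay on HeLa cells (Homo sapiens) for antiproliferative activity, read by CCK-8 assay, with a stated time of 72 h; a lower number here means a stronger inhibitor, a higher number a weaker inhibitor:
compound 1 `COc1ccc(-c2cncnc2-c2cc(OC)c(OC)c(OC)c2)cc1`: 1140 nM
compound 2 `COc1cc(-c2ncncc2-c2ccc(SC)cc2)cc(OC)c1OC`: 220 nM
compound 3 `COc1cc(-c2ncncc2-c2ccc(OCC(F)(F)F)cc2)cc(OC)c1OC`: 10200 nM

Compound 3 has the highest number of the three, making it the weakest inhibitor here. Compound 4 `COc1cc(-c2ncncc2-c2ccc(Br)cc2)cc(OC)c1OC` changes one group of compound 3: bromo in place of 2,2,2-trifluoroethoxy on an aromatic carbon. Three measured steps involve this same place. The large 46-fold higher number from compound 2 to compound 3 (1.67 log units; beyond the scatter) and the modest 8.9-fold higher number from compound 1 to compound 3 (0.95 log units; beyond the scatter) both rise towards compound 3, while a 5.2-fold lower number from compound 1 to compound 2 (0.71 log units; beyond the scatter) is modest. Within the data shown here, no bromo compound has been measured, so the expectation rests on compound 3 lying above both others. In this assay the expected change is a 17-fold lower number from compound 3 to compound 4 (1.23 log units; beyond the scatter), a large step to a lower number. For compound 4 the estimated value is 600 nM, with an expected range from 120 nM to 3000 nM.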

Compound 4, half-maximal inhibitory concentration: 500 nM
Compound 4: middle estimate off by 1.2-fold (0.08 log units), on the high side; low and high end bracket the measured number.
By their numbers in this assay, from the lowest: compound 2; then compound 4; then compound 1; then compound 3.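

In this assay, a single bromine atom at this place, para to a large group, recovers most of what 2,2,2-trifluoroethoxy loses: a 20-fold lower number from compound 3 to compound 4 (1.31 log units; beyond the scatter). Bromo also ranks in the middle of the other two groups, with a 2.3-fold higher number from compound 2 to compound 4 (0.36 log units; beyond the scatter) and a 2.3-fold lower number from compound 1 to compound 4 (0.36 log units; beyond the scatter), so compounds 1, 2 and 4 lie closer to each other than any of them lies to compound 3. Nothing available gives a reason for these differences. On these data alone, whether an amine, a carboxylic acid or a longer chain here would stay with those three compounds or rise towards compound 3 remains open.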